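Benzyl to methyl in a cytotoxicity series

The source may report more compounds than this note shows. Statements on the series, on what has been measured and on what is new or still open speak of the compounds shown alone.

Among the measured compounds shown here, compound 1 `c1ccc(Cc2nnc(-c3c[nH]c4ccccc34)o2)cc1` is the only member with a number in a functional assay on MCF7 cells (Homo sapiens) for cytotoxicity, read by MTT assay (a lower number here means a stronger inhibitor, a higher number a weaker inhibitor), where compound 1 gives 39200 nM. Compound 2 `COc1ccc(-c2nnc(-c3c[nH]c4ccccc34)o2)cc1` reaches only the assay limit, > 1000000 nM. Compound 3 `COc1cc(-c2nnc(-c3c[nH]c4ccccc34)o2)ccc1O` likewise reaches only the assay limit, > 1000000 nM. Two of the three values shown thus sit at the limit of > 1000000 nM in this assay, at which 2 of the 3 values shown sit, so compound 1 stands alone as the sole measurable point of the set. Compound 4 `Cc1nnc(-c2c[nH]c3ccccc23)o1` is not yet measured; it differs from compound 1 by hydrogen in place of phenyl on a saturated chain carbon bound to an aromatic carbon. For the measured compounds named here, no measured step of this kind exists among the three. The step is expected to be a weakening beyond the scatter, a 3.8-fold higher number from compound 1 to compound 4 (0.58 log units; beyond the scatter). The estimate for compound 4 is 150000 nM, range 30000 nM to 1000000 nM.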

Compound 4, half-maximal inhibitory concentration: 198000 nM
For compound 4 the middle estimate is 1.3-fold (0.12 log units) below the measured one; measured number inside the range.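

Among the compounds shown here, on a saturated chain carbon bound to an aromatic carbon, benzyl to methyl gives the first readable step in this assay (a 5.1-fold higher number from compound 1 to compound 4 (0.70 log units; beyond the scatter)), so in this pair phenyl at this place goes with the lower number. Compound 4 also shows that the core of compound 1 still gives a number with methyl alone. Compounds 2 and 3 remain limits and enter no comparison: the limit of > 1000000 nM in this assay, at which 2 of the 4 values shown sit.

Open, from the compounds shown here alone, is whether the phenyl ring itself matters or any larger group would do. A cyclohexyl group, a longer chain or an amine at this place would separate those readings.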